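Moving the Trifluoromethyl Group on a Weaker Urea Compound

The source may hold more compounds than are shown below. What is called first, only, known or untested is meant among the compounds shown, and "the series" means these compounds.

So far, three diaryl urea compounds have been tested in a functional assay on MDA-MB-231 cells (Homo sapiens) for antiproliferative activity, read by MTT assay, with a stated time of 72 h (a lower number here means a stronger inhibitor, a higher number a weaker inhibitor), and a fourth awaits its result. Compound 1 `CCN(CC)CCn1cnnc1-c1cc(Oc2ccc(NC(=O)Nc3cccc(C(F)(F)F)c3)cc2F)ccn1` gives 720 nM in this assay. Compound 2 `CCN(CC)CCn1cnnc1-c1cc(Oc2ccc(NC(=O)Nc3ccccc3C(F)(F)F)cc2F)ccn1` differs from compound 1 in one place only: 2-(trifluoromethyl)phenyl in place of 3-(trifluoromethyl)phenyl on an amide-type nitrogen. In this assay compound 2 gives 11600 nM, so this shift of the trifluoromethyl group loses a great deal, as the step of a 16-fold higher number from compound 1 to compound 2 (1.21 log units; beyond the scatter) shows. Compound 3 `CN(C)CCCn1cnnc1-c1cc(Oc2ccc(NC(=O)Nc3cccc(C(F)(F)F)c3)cc2F)ccn1` keeps the urea part of compound 1 but carries a different amine-bearing chain, and in this assay compound 3 gives 13300 nM, a loss of similar size: an 18-fold higher number from compound 1 to compound 3 (1.27 log units; beyond the scatter).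

Compound 4 `CN(C)CCCn1cnnc1-c1cc(Oc2ccc(NC(=O)Nc3ccccc3C(F)(F)F)cc2F)ccn1` has not yet been measured. It stands to compound 3 as compound 2 stands to compound 1, through the same change, (2-(trifluoromethyl)phenyl in place of 3-(trifluoromethyl)phenyl on an amide-type nitrogen), at a place described in exactly the same words, so it is the same change made for the second time. The two cores on which it is made differ as follows: (dimethylamino)methyl in place of diethylamino on a saturated chain carbon, two bonds along the chain from an aromatic nitrogen.

Going by the values given here, since the only earlier instance of this change gave the large step of a 16-fold higher number from compound 1 to compound 2 (1.21 log units; beyond the scatter), a step of comparable size and the same direction is expected for compound 4, with room left for a somewhat smaller step. The expected step is a 6.8-fold higher number from compound 3 to compound 4 (0.83 log units; beyond the scatter). Compound 4 is therefore estimated at about 90000 nM in this assay, most likely between 25000 nM and 300000 nM, with a fair chance that only a limit is reported.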

Compound 4, half-maximal inhibitory concentration: 40500 nM
For compound 4 the middle estimate is 2.2-fold (0.35 log units) above the measured one; low and high end bracket the measured number.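

In this assay, the trifluoromethyl shift again moves the number upward, a 3.0-fold higher number from compound 3 to compound 4 (0.48 log units; beyond the scatter), so the direction of the change carries from one core to the other, but its size does not: the same change on two cores in this assay, a 16-fold higher number (1.21 log units; beyond the scatter) from compound 1 to compound 2 and a 3.0-fold higher number (0.48 log units; beyond the scatter) from compound 3 to compound 4, 5.3-fold (0.72 log units) apart, beyond the scatter of two such steps The same holds when the pair is read the other way, with (dimethylamino)methyl in place of diethylamino on the chain, a 3.5-fold higher number from compound 2 to compound 4 (0.54 log units; beyond the scatter), which is again a loss, though a smaller one than on the compounds with 3-(trifluoromethyl)phenyl: the same change on two cores in this assay, an 18-fold higher number (1.27 log units; beyond the scatter) from compound 1 to compound 3 and a 3.5-fold higher number (0.54 log units; beyond the scatter) from compound 2 to compound 4, 5.3-fold (0.72 log units) apart, beyond the scatter of two such steps Together these steps show that the two changes do not simply add up in these four compounds, so a step measured on one core gives a reliable sign but not a reliable size on the other, although a single pair of cores cannot show why this happens or whether it would hold for a third core.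

Still open, as far as these compounds go, is whether the same direction and the same shrinking of the step would appear with a different amine, such as a morpholine or a pyrrolidine, or with a longer chain. From the compounds shown here alone, it is also open how the urea would behave if a chlorine took the place of the trifluoromethyl group on either core.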